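Benzyl variation at the aromatic nitrogen

A few compounds are considered here, and "the series" means these few. Any claim that something is new, unique, unknown or untested is made for them only; others in the source may bear on it.

Compound 1 `CCOC(=O)c1ccc(-c2nn(C)c3ccccc23)cc1` carries only a hydrogen on the saturated chain carbon bound to an aromatic nitrogen. In a functional assay on cells (Platelet, Homo sapiens) for inhibition (a lower number here means a stronger inhibitor, a higher number a weaker inhibitor), compound 1 gives > 10000 nM, which is a limit of the assay and not a number. Compound 2 `CCOC(=O)c1ccc(-c2nn(Cc3cccc(F)c3)c3ccccc23)cc1` places 3-fluorophenyl in place of hydrogen on a saturated chain carbon bound to an aromatic nitrogen. In this assay compound 2 gives > 10000 nM, again a limit of the assay. The step that the two limits leave unreadable from compound 1 to compound 2 is therefore not readable from the two limits. Both values sit at the limit of > 10000 nM in this assay, at which 2 of the 2 values shown sit, so compound 2 stands at the limit only, and no order within the pair can be read.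

Compound 3 `CCOC(=O)c1ccc(-c2nn(Cc3ccccc3OC)c3ccccc23)cc1` differs from compound 2 by 2-methoxyphenyl in place of 3-fluorophenyl on a saturated chain carbon bound to an aromatic nitrogen. Among the measured compounds shown here, the single measured step, from compound 1 to compound 2, touches the same place, yet its size is unknown, and neither value offers a number to anchor on. The change from compound 2 to compound 3 is expected to be a step that the limit leaves unreadable from compound 2 to compound 3 in this assay, nothing beyond the scatter. Compound 3 is estimated at 15000 nM in this assay, with a range from 5000 nM to 50000 nM, most likely reported again only as a limit.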

Compound 3, half-maximal inhibitory concentration: > 10000 nM
Compound 3: no number, only a limit (the forecaster's own chance of this, stated with the estimate: 75%); the middle value lies beyond the limit too.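

Compound 3 gives > 10000 nM in this assay as a limit of the assay and not a number. Among the compounds shown here, no step among compound 1, compound 2 and compound 3 can be read: the limit of > 10000 nM in this assay, at which 3 of the 3 values shown sit. The compounds shown leave open whether any group on the saturated chain carbon bound to an aromatic nitrogen changes inhibition in this assay at all.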